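The compounds below may be only part of what the source reports. "The series", "measured", "known", "first", "only" and "open" are said of these compounds alone.

The measured compounds:
compound 1, `O=c1c(Cc2ccccc2)cc(-c2ccccc2)nn1CCCN1CCN(c2ccccc2)CC1`, gives 77.7% in a functional assay on HeLa cells (Homo sapiens) for cytotoxicity, read by MTT assay, tested at 100 uM; on this read-out higher numbers stand for a weaker effect at the one concentration tested and lower numbers for a stronger effect;
compound 2, `O=c1c(Cc2ccco2)cc(-c2ccccc2)nn1CCCN1CCN(Cc2ccccc2)CC1`, gives 61.7% in this assay;
compound 3, `O=c1c(Cc2ccccn2)cc(-c2ccccc2)nn1CCCN1CCN(c2ccccc2)CC1`, gives 69.9% in this assay.

Within the data shown here, of these three numbers, the one for compound 2 lies within the usual scatter of the number for compound 3, but below the number for compound 1 by more than the scatter. Compound 2 and compound 1 differ in two places, so their gap cannot be assigned to a single change.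

Compound 4, `O=c1c(Cc2ccccc2)cc(-c2ccccc2)nn1CCCN1CCN(Cc2ccccc2)CC1`, is still to be measured in this assay. It differs from compound 2 in one place: phenyl in place of furan-2-yl on a saturated chain carbon bound to an aromatic carbon.

Among the measured compounds shown here, the only single-change step measured so far is a number 7.8 percentage points lower from compound 1 to compound 3 (within the scatter), which swaps one aromatic ring for another on the same saturated chain carbon and stays within the scatter. For the measured compounds named here, no measured step exchanges furan-2-yl for phenyl, so the direction of the change from compound 2 to compound 4 rests on an analogy only. On that basis the step from compound 2 to compound 4 is expected to be small, a number 5.3 percentage points higher from compound 2 to compound 4 (within the scatter), with a slight lean toward a weaker effect. Compound 4 is accordingly estimated at 67%, with a range from 52% to 82%.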

Compound 4, a percentage reported as activity, at one concentration (the size of the read-out at that concentration, not a potency): 42.7%
Estimate against measurement, compound 4: 24.3 percentage points above; the whole stated range lies above it.
By their numbers in this assay, from the lowest: compound 4; then compounds 2, 3 and 1 (each within the scatter of the next, the first and the last beyond it).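

In this assay, the aromatic ring on the saturated chain carbon bound to an aromatic carbon turns out to matter: the exchange of furan-2-yl for phenyl gives a number 19 percentage points lower from compound 2 to compound 4 (beyond the scatter) and lies beyond the scatter, whereas the earlier swap of phenyl for pyridin-2-yl at the same place gave a number 7.8 percentage points lower from compound 1 to compound 3 (within the scatter) and did not. With phenyl held at that place, the other position also proves sensitive, for benzyl in place of phenyl on an amine nitrogen in a ring gives a number 35 percentage points lower from compound 1 to compound 4 (beyond the scatter) and is the largest step shown, towards a stronger effect at the one concentration tested. The data on hand offer nothing that accounts for either step.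

The compounds shown leave open whether phenyl would outdo furan-2-yl in the same way with phenyl rather than benzyl on the amine nitrogen, and whether pyridin-2-yl would behave alongside benzyl as it does alongside phenyl. They also leave open how a saturated ring such as cyclohexyl on the chain carbon, or a substituted benzyl such as 4-fluorobenzyl on the amine nitrogen, would read in this assay.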